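Keto-amide chain series: removing one aryl methyl

The compounds below may be only part of what the source reports. "The series", "measured", "known", "first", "only" and "open" are said of these compounds alone.

Measured so far in a functional assay on the whole organism (Central nervous system) with Mus musculus as the target; on this read-out higher numbers stand for an effect only at larger amounts of compound and lower numbers for an effect already at smaller amounts:
compound 1 `O=C1CCC2(c3ccc(Cl)c(Cl)c3)OCCCN12` gives < 150 mg/kg
compound 2 `O=C(CCC(=O)c1ccc(Cl)cc1)NCCCO` gives 325 mg/kg
compound 3 `Cc1ccc(C(=O)CCC(=O)NCCCO)c(C)c1` gives 150 mg/kg

The value of compound 1 is a limit of the assay, so only the limit of < 150 mg/kg in this assay, at which 1 of the 3 values shown sits, is known for it. Of the two numbers, compound 3 stands lowest, with compound 2 the nearest and higher by a gap beyond the scatter.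

Compound 4 `Cc1ccc(C(=O)CCC(=O)NCCCO)cc1` differs from compound 3 by hydrogen in place of methyl on an aromatic carbon. Within the data shown here, no measured pair in the set shows this change alone; compound 2 and compound 3 differ at several places, so their values give only orientation. The expected step is a 1.3-fold higher number from compound 3 to compound 4 (0.12 log units; within the scatter), small and toward a higher number, around the edge of the scatter. Compound 4 is estimated to give 200 mg/kg in this assay, with a range from 110 mg/kg to 380 mg/kg.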

Compound 4, dose for half-maximal effect: 700 mg/kg
The estimate for compound 4 lay 3.5-fold (0.54 log units) below the measured number; measured number above the stated range.
By their numbers in this assay, from the lowest: compound 3; then compound 2; then compound 4.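

In this assay the methyl ortho to a large group counts for more than the small step expected: hydrogen in its place brings a 4.7-fold higher number from compound 3 to compound 4 (0.67 log units; beyond the scatter). With that position carrying hydrogen, methyl in place of chloro on an aromatic carbon brings a 2.2-fold higher number from compound 2 to compound 4 (0.33 log units; beyond the scatter). Nothing measured here accounts for either step.

As far as these compounds go, whether a methoxy or ethyl group on that same aromatic carbon would retain the effect of the methyl remains open. So does the effect of a longer chain in place of the hydroxypropyl amide.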